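Diaryl urea series: methoxyphenyl for dimethylphenyl on a second core

The source may report more compounds than this note shows. Statements on the series, on what has been measured and on what is new or still open speak of the compounds shown alone.

Measured so far in a functional assay on HepG2 cells (Homo sapiens) for inhibition, with a stated time of 72 h; on this read-out lower numbers stand for stronger inhibition and higher numbers for weaker inhibition:
- compound 1, `COc1ccc(NC(=O)Nc2nc(Sc3c[nH]c4ccccc34)cc(N3CCCCC3)n2)cc1`, gives 17100 nM
- compound 2, `Cc1ccc(C)c(NC(=O)Nc2nc(Sc3c[nH]c4ccccc34)cc(N3CCCCC3)n2)c1`, gives 6440 nM
- compound 3, `Cc1ccc(C)c(NC(=O)Nc2nc(Sc3c[nH]c4ccccc34)cc(N3CCN(Cc4ccccc4)CC3)n2)c1`, gives 16400 nM

One change has a measured step. Between compound 2 and compound 1 the change is 4-methoxyphenyl in place of 2,5-dimethylphenyl on an amide-type nitrogen, and in this assay it made a 2.7-fold higher number from compound 2 to compound 1 (0.42 log units; beyond the scatter).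

Compound 3 carries a different core from compound 2; the difference between the two cores is not broken down here. In this assay compound 3 stands beyond the scatter from compound 2 and within the scatter of compound 1, so no order between compound 3 and compound 1 is claimed.

Compound 4, `COc1ccc(NC(=O)Nc2nc(Sc3c[nH]c4ccccc34)cc(N3CCN(Cc4ccccc4)CC3)n2)cc1`, is not yet measured. It differs from compound 3 by 4-methoxyphenyl in place of 2,5-dimethylphenyl on an amide-type nitrogen. The place of this change reads the same, word for word, as the place of the change from compound 2 to compound 1, so the two are the same change, made on the two different cores. Among the compounds with values here, only this one measured instance is available; nothing says whether the core of compound 3 carries the change in the same way.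

For compound 4 in this assay the expected step is a 2.3-fold higher number from compound 3 to compound 4 (0.36 log units; beyond the scatter), taken beside a 2.7-fold higher number from compound 2 to compound 1 (0.42 log units; beyond the scatter), and it rests on compound 2 and compound 1 alone. Within the data shown here, the expected value for compound 4 is 38000 nM, with a range from 15000 nM to 95000 nM; the upper end is wide because compound 3 already gives 16400 nM and a further step in the same direction goes beyond every number measured so far.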

Compound 4, half-maximal inhibitory concentration: 21400 nM
The estimate for compound 4 lay 1.8-fold (0.25 log units) above the measured number; the measured number falls inside the stated range.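

In this assay, 4-methoxyphenyl in place of 2,5-dimethylphenyl on an amide-type nitrogen gives a 1.3-fold higher number from compound 3 to compound 4 (0.12 log units; within the scatter), so on the core of compound 3 this step alone does not stand clear of the scatter. Set beside the earlier instance, the two steps cannot be told apart: the same change on two cores in this assay, a 2.7-fold higher number (0.42 log units; beyond the scatter) from compound 2 to compound 1 and a 1.3-fold higher number (0.12 log units; within the scatter) from compound 3 to compound 4, 2.0-fold (0.31 log units) apart, within the scatter of two such steps. This fits one shared step on both cores but does not show that the change carries over unaltered: one step lies beyond the scatter and the other within it, and a single pair on each core cannot tell a smaller step on the core of compound 3 from a step of equal size hidden by scatter.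

The compounds shown leave open whether the step would hold on a third core, and which part of the change matters, as the methoxy group enters and both methyl groups leave in one move; an unsubstituted phenyl or a phenyl with a single methyl would separate these. Also open, as far as these compounds go, is how the urea aryl group behaves when it carries an amine or a carboxylic acid in place of the methoxy group.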